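The source may report more compounds than this note shows. Statements on the series, on what has been measured and on what is new or still open speak of the compounds shown alone.

Measured compounds in a physicochemical assay for permeability, using PAMPA; a lower number here means that the compound crosses the layer more slowly, a higher number that the compound crosses the layer faster:
- compound 1 `C[C@@H](Oc1cc2oc(=O)n(CCC(=O)O)c2cc1Cl)c1ccc(F)cn1` gives 31 nm/s
- compound 2 `CCOc1cc2oc(=O)n(CCC(=O)O)c2cc1Cl` gives < 10 nm/s, which is a limit of the assay and not a number

Compound 2 stands at the limit of < 10 nm/s in this assay, at which 1 of the 2 values shown sits, so the measured set fixes only an upper bound for it. Among the measured compounds shown here, the one measured step, an at least 3.1-fold lower number from compound 1 to compound 2 (0.49 log units; beyond the scatter), concerns the chain carbon bound to the ring oxygen, and it carries compound 2 down to the limit.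

Compound 3 `O=C(O)CCn1c(=O)oc2cc(Cl)c(Cl)cc21` is not yet measured. It differs from compound 2 by chloro in place of ethoxy on an aromatic carbon. For the measured compounds named here, no measured step touches this position or this kind of exchange: the step from compound 1 to compound 2 changes a different part of the molecule, so it gives no direct guide to the size or direction of the change from ethoxy to chloro. For compound 3 the expected step in this assay is therefore an at least 1.2-fold higher number from compound 2 to compound 3 (0.07 log units; that floor lies within the scatter), with no firm direction beyond the scatter. Compound 3 is estimated to give 12 nm/s, within a range of 5 nm/s to 30 nm/s, and a reading that again stops at the assay limit is considered quite possible.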

Compound 3, apparent permeability: 24 nm/s
For compound 3 the middle estimate is 2.0-fold (0.30 log units) below the measured one, and the stated range covers the measured number.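

In this assay, chloro in place of ethoxy on this aromatic carbon gives an at least 2.4-fold higher number from compound 2 to compound 3 (0.38 log units; beyond the scatter), so this position can move the read-out by more than the usual scatter. The earlier step changed only the chain carbon bound to the ring oxygen, whereas this one shows that the read-out also responds to an exchange made directly on the aromatic carbon ortho to a chloro group, with the shared core and the acid chain unchanged. Compound 2 gives < 10 nm/s, which is a limit of the assay and not a number, so the step is only a floor and its full size remains unfixed: the limit of < 10 nm/s in this assay, at which 1 of the 3 values shown sits.

Only ethoxy and chloro can be compared directly here, and because this exchange replaces three heavy atoms, including an oxygen, with one chlorine, the compounds shown cannot separate the contribution of the lost oxygen from that of the entering chlorine; a methyl, a methoxy or a fluoro on this carbon would help to settle that. Also open, as far as these compounds go, is whether the step would keep its direction and size with an amide in place of the carboxylic acid.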